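Isopropyl ester in place of the nitrate-bearing side chain

The compounds below may be only part of what the source reports. "The series", "measured", "known", "first", "only" and "open" are said of these compounds alone.

Measured so far:
Compound 1 `CC1=C(C(=O)OCCO[N+](=O)[O-])C(c2cccc3nonc23)C([N+](=O)[O-])=C(C)C1` gives 31100 nM
Compound 2 `CC1=C(C(=O)O[C@H](C)CO[N+](=O)[O-])[C@H](c2cccc3nonc23)C([N+](=O)[O-])=C(C)C1` gives 1920 nM
Compound 3 `CC1=C(C(=O)OCC(C)O[N+](=O)[O-])C(c2cccc3nonc23)C([N+](=O)[O-])=C(C)C1` gives 972 nM

All three numbers come from a functional assay (cardiac atrium) for agonist activity, with Cavia porcellus as the target; on this read-out lower numbers stand for an effect already at smaller amounts and higher numbers for an effect only at larger amounts of compound. Compound 3 has the lowest number of the three; compound 2 lies within the scatter of it, while compound 1 stands far higher. Within the data shown here, the one single-point step among the measured compounds is a 32-fold lower number from compound 1 to compound 3 (1.51 log units; beyond the scatter), a large movement downward, whereas the values of compound 2 and compound 3 differ only within the scatter.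

Compound 4 `CC1=C(C(=O)OC(C)C)C(c2cccc3nonc23)C([N+](=O)[O-])=C(C)C1` has not been measured in this assay. It differs from compound 3 in the ester: a group of 3 heavy atoms (3 carbon; no ring) in place of a group of 7 heavy atoms (3 carbon, 1 nitrogen, 3 oxygen; no ring), on an oxygen next to a carbonyl group. The step from compound 1 to compound 3 shows that the ester side chain is a place where a small change can move the number a long way, but it involved adding a methyl, not removing the whole nitrate-bearing chain, so it bears only loosely on the present step. With only this to go on, compound 4 is expected to move by a 2.4-fold lower number from compound 3 to compound 4 (0.39 log units; beyond the scatter) in this assay, a modest step toward a lower number that might also turn out to be none beyond the scatter. Compound 4 is estimated at 400 nM, with a range from 80 nM to 2000 nM.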

Compound 4, half-maximal effective concentration: 9400 nM
Beside the measured number, compound 4's estimate is 24-fold (1.37 log units) below it, outside the stated range (above it).
By their numbers in this assay, from the lowest: compounds 3 and 2 (each within the scatter of the next); then compound 4; then compound 1.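

In this assay, the isopropyl group in place of the nitrate-bearing chain gives a 9.7-fold higher number from compound 3 to compound 4 (0.99 log units; beyond the scatter), so at this position on the oxygen next to a carbonyl group, the low number of compound 3 does not survive the loss of its whole chain. The nitrate alone does not set the number, however: the other single-place comparison gives a 3.3-fold lower number from compound 1 to compound 4 (0.52 log units; beyond the scatter), and compound 1 goes against any rule that a nitrate-bearing chain gives the lower number, since its unbranched 2-(nitrooxy)ethyl chain stands higher than the isopropyl group that has no nitrate. The ester side chain therefore matters here both through the presence of the nitrate and through the methyl on its chain, but nothing measured accounts for either step.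

The compounds shown leave open whether a hydroxyl group in place of the nitrate on the methyl-bearing chain would stay close to compound 3 or move toward compound 4. They also leave open how a longer chain carrying the nitrate, such as a 3-(nitrooxy)propyl group, would read in this assay.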